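The source may hold more compounds than are shown below. What is called first, only, known or untested is meant among the compounds shown, and "the series" means these compounds.

In a functional assay on HL-60 cells (Homo sapiens) for cytotoxicity (on this read-out lower numbers stand for stronger inhibition and higher numbers for weaker inhibition), compound 1 `COc1c(O)cc2c3c1C[C@@H](C)C[C@H](OC)[C@H](O3)[C@@H](C)/C=C(\C)[C@H](OC(N)=O)[C@@H](OC)CC/C=C(\C)C(=O)N2` gives 86000 nM, and compound 2 `COc1c(O)cc2c3c1C[C@@H](C)C[C@H](OC)[C@H](O3)[C@@H](C)/C=C(\C)[C@H](OC(N)=O)[C@@H](OC)/C=C\C=C(/C)C(=O)N2` gives 27000 nM. Compound 2 therefore holds the lower of the two numbers, and the gap to compound 1 lies beyond the usual scatter. Compound 3 `COc1c(O)cc2c3c1C[C@@H](C)C[C@H](OC)[C@H](O3)[C@@H](C)/C=C(\C)[C@H](OC(N)=O)[C@@H](OC)/C=C/C=C(\C)C(=O)N2` has not yet been measured. It departs from compound 2 in a single respect: the two compounds have the same atoms and bonds and differ only in configuration as drawn: 1 of 9 stereo elements differ; a double bond is drawn Z in compound 2 and E in compound 3. Going by the values given here, no pair of measured compounds shows a change of this kind, so the data give no direct guide to its size or direction. With only the configuration of one double bond altered, the expectation in this assay is a step no larger than the scatter, with a slight lean towards a higher number. That expectation takes compound 2 at 27000 nM as its anchor. The expected size of the change is a 1.3-fold higher number from compound 2 to compound 3 (0.11 log units; within the scatter). The wide range below allows for the lack of any measured precedent. For compound 3 the estimated value is 35000 nM, with an expected range from 10000 nM to 100000 nM.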

Compound 3, half-maximal inhibitory concentration: 35000 nM
For compound 3 middle estimate and measured number coincide at the digits printed; the measured number falls inside the stated range.
By their numbers in this assay, from the lowest: compounds 2 and 3 (each within the scatter of the next); then compound 1.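

Reversing the geometry of this one double bond, a kind of change no earlier pair of compounds carried, gives in this assay a 1.3-fold higher number from compound 2 to compound 3 (0.11 log units; within the scatter). At this position, then, the Z and E forms cannot be told apart on this read-out, and compound 3, at 35000 nM, stands level with compound 2 within the scatter. The comparison isolates the double-bond geometry alone, because nothing else separates the two structures, as the pair's computed difference confirms: the fact that compounds 2 and 3 differ only in the configuration as drawn.

The compounds shown leave open whether an amine or a carboxylic acid added to the shared core would move the number in this assay beyond the scatter, since every structure here keeps the same substituents on that core. They also leave open whether the same change of geometry would stay this small in a compound carrying a longer chain, and a single pair gives no sign of how far this near-silent step extends to other double bonds in the core.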